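Replacing the methylsulfanyl group of compound 2

A few compounds are considered here, and "the series" means these few. Any claim that something is new, unique, unknown or untested is made for them only; others in the source may bear on it.

Measured in an ADME assay on L6 cells (Rattus norvegicus) for inhibition, read by resazurin assay, with a stated time of 72 h (on this read-out higher numbers stand for weaker inhibition and lower numbers for stronger inhibition), as follows:
- compound 1 `CSC[C@H]1O[C@@H](n2cnc3c(N)nc(F)nc32)[C@H](OC(C)=O)[C@@H]1OC(C)=O` gives 15000 nM
- compound 2 `CSC[C@H]1O[C@@H](n2cnc3c(N)nc(Cl)nc32)[C@H](OC(C)=O)[C@@H]1OC(C)=O` gives 216000 nM

Compound 2 gives 216000 nM as the higher number of the two, which marks the weaker inhibition here. Compound 3 `CC(=O)O[C@@H]1[C@H](OC(C)=O)[C@@H](C[S+](C)[O-])O[C@H]1n1cnc2c(N)nc(Cl)nc21` differs from it in one place: a group of 3 heavy atoms (1 carbon, 1 oxygen, 1 sulfur; no ring) in place of a group of 2 heavy atoms (1 carbon, 1 sulfur; no ring), on a saturated chain carbon bound to a saturated ring carbon on a saturated chain carbon bound to a saturated ring carbon. Within the data shown here, the only measured step, a 14-fold higher number from compound 1 to compound 2 (1.16 log units; beyond the scatter) for chloro in place of fluoro on an aromatic carbon, is large but concerns a different place. Among the measured compounds shown here, no measured step touches the methylsulfanyl group, so the data give no direction, and no step beyond the scatter is expected in this assay for this change. The expected step is a 1.1-fold lower number from compound 2 to compound 3 (0.03 log units; within the scatter) at this stage. Compound 3 is estimated at 200000 nM within 70000 nM to 400000 nM as the expected range.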

Compound 3, half-maximal inhibitory concentration: 168000 nM
Compound 3: the middle estimate sits 1.2-fold (0.08 log units) above what was measured; the measured number falls inside the stated range.
By their numbers in this assay, from the lowest: compound 1; then compounds 3 and 2 (each within the scatter of the next).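

In this assay, among these compounds, the exchange on a saturated chain carbon bound to a saturated ring carbon gives a 1.3-fold lower number from compound 2 to compound 3 (0.11 log units; within the scatter), the first reading at this position, and it lies within the scatter. With the chloro group in place, the methylsulfanyl group can therefore give way to the group of compound 3 with no measurable step, whereas the only large step shown so far remains the chloro-for-fluoro exchange on an aromatic carbon. No evidence is available that would explain this result.

As far as these compounds go, whether the same exchange on compound 1, which carries fluoro, would also stay within the scatter remains open. Also open, from the compounds shown here alone, is whether a methylsulfonyl group, an amine or a longer chain at this position would shift the number beyond the scatter.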